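The source may hold more compounds than are shown below. What is called first, only, known or untested is meant among the compounds shown, and "the series" means these compounds.

Compound 1 `Cn1cc(-c2cnc(N)c(Oc3ccc(C(=O)Nc4ccccc4)cc3)n2)cn1`: in a functional assay on LoVo cells (Homo sapiens) for inhibition, read by MTT assay, with a stated time of 72 h (on this read-out lower numbers stand for stronger inhibition and higher numbers for weaker inhibition), compound 1 gives 9210 nM.
Compound 2 `Cn1cc(-c2cnc(N)c(Oc3ccc(C(=O)Nc4ccccc4Cl)cc3)n2)cn1`: in this assay compound 2 gives 41400 nM.
Compound 3 `Cn1cc(-c2cnc(N)c(Oc3ccc(C(=O)Nc4ccc(Cl)cc4)cc3)n2)cn1`: in this assay compound 3 gives 3080 nM.

Compound 3 has the lowest number of the three, and both of its steps to the others lie beyond the scatter, so it stands as the strongest inhibitor measured. The steps show how the place of the chlorine matters: a 4.5-fold higher number from compound 1 to compound 2 (0.65 log units; beyond the scatter), whereas a 3.0-fold lower number from compound 1 to compound 3 (0.48 log units; beyond the scatter), and a 13-fold lower number from compound 2 to compound 3 (1.13 log units; beyond the scatter).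

Compound 4 `Cn1cc(-c2cnc(N)c(Oc3ccc(C(=O)Nc4cccc(Cl)c4)cc3)n2)cn1` has not yet been measured. It differs from compound 3 by 3-chlorophenyl in place of 4-chlorophenyl on an amide-type nitrogen. Within the data shown here, no measured step covers this exact change, but the two chlorine steps from compound 1 frame it: one place gave a weaker result, the other a stronger one, and the 3-chlorophenyl is a third place. The expectation is therefore a number somewhere between those of compound 1 and compound 3, giving an expected step of a 1.9-fold higher number from compound 3 to compound 4 (0.29 log units; within the scatter) in this assay. For compound 4 the estimated value is 6000 nM, with a range from 2000 nM to 20000 nM.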

Compound 4, half-maximal inhibitory concentration: 24500 nM
For compound 4 the middle estimate is 4.1-fold (0.61 log units) below the measured one, outside the stated range (above it).
By their numbers in this assay, from the lowest: compound 3; then compound 1; then compounds 4 and 2 (each within the scatter of the next).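

Changing the 4-chlorophenyl to the 3-chlorophenyl on the amide nitrogen is not a small adjustment in this assay (an 8.0-fold higher number from compound 3 to compound 4 (0.90 log units; beyond the scatter)), even though the two groups hold the same atoms. The chloro step from the plain phenyl now also gives a weaker result (a 2.7-fold higher number from compound 1 to compound 4 (0.42 log units; beyond the scatter)), so the 3-chlorophenyl sides with the 2-chlorophenyl of compound 2 and not with the 4-chlorophenyl of compound 3. Compound 2 and compound 4 cannot be told apart (a 1.7-fold lower number from compound 2 to compound 4 (0.23 log units; within the scatter)), which leaves compound 3 as the only one of the three chloro compounds that improves on compound 1.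

Nothing given here accounts for this dependence on where the chlorine sits. Going by these compounds, whether a methoxy group or a nitrile in place of the chlorine of the 4-chlorophenyl would give a number like that of compound 3 remains open.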